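From methoxyphenyl to difluorophenyl on the carbonyl carbon

The source may hold more compounds than are shown below. What is called first, only, known or untested is meant among the compounds shown, and "the series" means these compounds.

compound 1 `COc1cc(-c2cc(/C=C/C(=O)c3ccc(Cl)c(Cl)c3)[nH]n2)cc(OC)c1OC`: 23500 nM
compound 2 `COc1ccc(C(=O)/C=C/c2cc(-c3cc(OC)c(OC)c(OC)c3)n[nH]2)cc1`: 5850 nM

In a functional assay on CCRF-CEM cells (Homo sapiens) for inhibition, read by sulforhodamine B assay, with a stated time of 48 h (a higher number here means a weaker inhibitor of growth, a lower number a stronger inhibitor of growth), compound 2 gives 5850 nM, the lowest of the two numbers; its nearest neighbour is compound 1, with a 4.0-fold lower number from compound 1 to compound 2 (0.60 log units; beyond the scatter). Compound 3 `COc1cc(-c2cc(/C=C/C(=O)c3ccc(F)c(F)c3)[nH]n2)cc(OC)c1OC` differs from compound 2 by 3,4-difluorophenyl in place of 4-methoxyphenyl on a carbonyl carbon. Within the data shown here, the only measured step bearing on this is a 4.0-fold lower number from compound 1 to compound 2 (0.60 log units; beyond the scatter), where 3,4-dichlorophenyl gave way to 4-methoxyphenyl; compound 3 brings a 3,4-dihalogenated ring back in place of the 4-methoxyphenyl. A modest upward step is therefore expected, a 2.6-fold higher number from compound 2 to compound 3 (0.41 log units; beyond the scatter). In this assay compound 3 is estimated at 15000 nM, within 5000 nM to 45000 nM.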

Compound 3, concentration for total growth inhibition: 47200 nM
The estimate for compound 3 lay 3.1-fold (0.50 log units) below the measured number; the whole stated range lies below it.
By their numbers in this assay, from the lowest: compound 2; then compounds 1 and 3 (each within the scatter of the next).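

In this assay, 3,4-difluorophenyl on the carbonyl carbon shows an 8.1-fold higher number from compound 2 to compound 3 (0.91 log units; beyond the scatter), a second dihalogenated ring that falls on the weaker side of 4-methoxyphenyl. The two dihalogenated rings cannot be told apart, with a 2.0-fold higher number from compound 1 to compound 3 (0.30 log units; within the scatter), so among these three groups the 4-methoxyphenyl alone stands apart at this position. Nothing given here accounts for this difference. The compounds shown leave open whether the advantage of compound 2 belongs to the methoxy group itself, or whether a hydroxyl or an amine on that ring, or an unsubstituted phenyl, would match it.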